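The source may report more compounds than this note shows. Statements on the series, on what has been measured and on what is new or still open speak of the compounds shown alone.

Two compounds of the series have numbers in an assay on HEK293 cells for inhibition of Indoleamine 2,3-dioxygenase 1 (Homo sapiens), tested at 10 uM (on this read-out higher numbers stand for more inhibition at the one concentration tested (going by the name of the read-out) and lower numbers for less inhibition), so far. Compound 1 `CC(C)C(=O)N1CCc2cc(CNC(=O)c3ccc(Cl)cc3)ccc21` gives 92% and stands highest of the two. Among the measured compounds shown here, compound 2 `CC(C)NC(=O)NCc1ccc2c(c1)CCN2C(=O)c1ccccc1` gives 45% in this assay, a gap below compound 1 that lies beyond the scatter; as the two structures differ in more than one place, their values show only that compound 1 sits clearly higher. Compound 3 `CC(C)C(=O)N1CCc2cc(CNC(=O)c3cccs3)ccc21` has not yet been measured in this assay. It differs from compound 1 in one place, on the carbonyl carbon of the amide: thiophen-2-yl in place of 4-chlorophenyl on a carbonyl carbon. Both the group that leaves and the one that enters are aromatic rings, and the rest of the structure is unchanged. The expected change is a number 16 percentage points lower from compound 1 to compound 3 (beyond the scatter), a modest loss that may stay within the scatter or reach a little beyond it. Compound 3 is accordingly estimated at 76% in this assay, with a range from 52% to 92%.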

Compound 3, a percentage reported as inhibition, at one concentration (the size of the read-out at that concentration, not a potency): 100%
The estimate for compound 3 lay 24 percentage points below the measured number, and the stated range ends below it.
By their numbers in this assay, from the lowest: compound 2; then compounds 1 and 3 (each within the scatter of the next).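

In this assay, thiophen-2-yl in place of 4-chlorophenyl on a carbonyl carbon whose other neighbours are amide-type nitrogen gives a number 8 percentage points higher from compound 1 to compound 3 (within the scatter). This position therefore accepts a five-membered aromatic ring with one hetero atom as well as a six-membered aromatic ring of carbon only, and the chlorine atom is not required for a high number on this core. Nothing measured here bears on why the two groups give values that cannot be told apart.

Still open, on these data alone, is whether a group without an aromatic ring, such as cyclohexyl or piperidin-4-yl, keeps a high number on this carbonyl carbon. As far as these compounds go, the read-out in this assay comes from one concentration, so the relative potency of compound 1 and compound 3 also remains open.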